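The source may hold more compounds than are shown below. What is called first, only, known or untested is meant among the compounds shown, and "the series" means these compounds.

Working notes on the series.

Two compounds of this set have a number in a functional assay on MDA-MB-231 cells (Homo sapiens) for cytotoxicity, read by neutral red uptake, with a stated time of 72 h; a higher number here means a weaker inhibitor, a lower number a stronger inhibitor. Compound 1 `CCCCCNc1nc(SCC)nc2ncccc12` gives in this assay 1300 nM. Compound 2 `CCCCNc1nc(SCCCC)nc2ncccc12` gives in this assay 8400 nM, the highest of the two numbers; compound 1 is the nearest, and the gap between the two values is beyond the scatter. Compound 1 and compound 2 differ in two places at once, so no single step can be read from that pair.

Compound 3 `CCCCCNc1nc(SCCCC)nc2ncccc12` is not yet measured. It differs from compound 2 by methyl in place of hydrogen on a saturated chain carbon, four bonds along the chain from a nitrogen on an aromatic ring, so that the difference, cut one bond further out, reads butyl to pentyl on the amine side. Among the compounds with values here, with no step between measured compounds to lean on, the direction of the change in this assay is open; compound 1, which carries the same pentyl amine, gives 1300 nM, but its sulfur-side chain is shorter, and that cannot be separated out. The expected step from compound 2 to compound 3 is therefore small, a 1.7-fold lower number from compound 2 to compound 3 (0.23 log units; within the scatter), not beyond the scatter. Compound 3 is estimated at 5000 nM, with a range from 1500 nM to 15000 nM.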

Compound 3, half-maximal inhibitory concentration: 6300 nM
Compound 3: the middle estimate sits 1.3-fold (0.10 log units) below what was measured, and the stated range covers the measured number.
By their numbers in this assay, from the lowest: compound 1; then compounds 3 and 2 (each within the scatter of the next).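

In this assay, within the data shown here, the change of methyl in place of hydrogen on a saturated chain carbon, four bonds along the chain from a nitrogen on an aromatic ring, now has a first reading of a 1.3-fold lower number from compound 2 to compound 3 (0.12 log units; within the scatter) and so, on the butyl to pentyl change at this position, the amine-side chain does not separate the pair. Among these compounds, with the pentyl amine held constant, ethyl in place of hydrogen on a saturated chain carbon, two bonds along the chain from a sulfur, gives a 4.8-fold higher number from compound 1 to compound 3 (0.69 log units; beyond the scatter) as the first single change in the set to lie beyond the scatter. Within these pairs the gap therefore sits with the sulfur-side chain and not with the amine-side chain, and nothing at hand bears on why the two chains differ in this way.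

Among the compounds shown here, with only two lengths read on each side, the shape of the trend on the sulfur-side chain remains open, including whether a methyl or propyl chain there would fall in line with the ethyl and butyl readings. Also open, from the compounds shown here alone, is how a longer chain such as hexyl, a branched chain or a terminal hydroxyl would read on the amine side.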